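A few compounds are considered here, and "the series" means these few. Any claim that something is new, unique, unknown or untested is made for them only; others in the source may bear on it.

In a functional assay on RAW264.7 cells (Mus musculus) for inhibition (a lower number here means a stronger inhibitor, a higher number a weaker inhibitor), three compounds have been measured so far:

Compound 1 `CCOC(=O)C1=CCCCC1S(=O)(=O)Nc1ccccc1` gives 260 nM
Compound 2 `CCOC(=O)C1=CCCCC1S(=O)(=O)Nc1ccccc1F` gives 75 nM
Compound 3 `CCOC(=O)C1=CCCCC1S(=O)(=O)Nc1ccccc1Cl` gives 12 nM

Compound 3 has the lowest number of the three and is the strongest inhibitor among them, with both of its gaps to the others beyond the scatter. Compound 4 `CCOC(=O)C1=CCCCC1S(=O)(=O)Nc1ccccc1CC` has not yet been measured. It carries ethyl in place of chloro on an aromatic carbon, ortho to a large group (ethyl in place of chloro on an aromatic carbon).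

Among the measured compounds shown here, three measured steps bear on this change, all at the same place. The step of a 3.5-fold lower number from compound 1 to compound 2 (0.54 log units; beyond the scatter) was modest, the step of a 22-fold lower number from compound 1 to compound 3 (1.34 log units; beyond the scatter) was large, and the step of a 6.3-fold lower number from compound 2 to compound 3 (0.80 log units; beyond the scatter) was modest. The last of these shows that exchanging one group for another there can move the number well beyond the scatter. For the measured compounds named here, no measured compound has a carbon group at this place, so the direction rests on weak evidence. Compound 3 is the lowest of the series, and some loss from it seems more likely than a further gain. The expected step is a 3.3-fold higher number from compound 3 to compound 4 (0.52 log units; beyond the scatter) and this estimated rise is modest in size. In this assay compound 4 is estimated at 40 nM with an expected range from 12 nM to 150 nM for this value.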

Compound 4, half-maximal inhibitory concentration: 130 nM
Compound 4: middle estimate off by 3.3-fold (0.51 log units), on the low side, within the range that was stated.
By their numbers in this assay, from the lowest: compound 3; then compounds 2, 4 and 1 (each within the scatter of the next, the first and the last beyond it).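

In this assay, among the compounds shown here, ethyl is the first carbon group seen at this place, and exchanging chloro for it takes away much of the earlier gain, with an 11-fold higher number from compound 3 to compound 4 (1.03 log units; beyond the scatter) marking a large step in the weaker direction. Ethyl cannot be told apart from fluoro, with a 1.7-fold higher number from compound 2 to compound 4 (0.24 log units; within the scatter) printed as within the scatter, and it cannot be told apart from hydrogen either, with a 2.0-fold lower number from compound 1 to compound 4 (0.30 log units; within the scatter) also within the scatter, even though compound 1 and compound 2 differ from each other beyond the scatter. Among the four groups seen here, the low number therefore belongs to chloro alone and does not come with just any group at this place, but nothing measured here accounts for the difference.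

On these data alone, whether methyl, bromo or methoxy at this place would stand with chloro or with ethyl remains open, as does how a longer chain or an amine would compare. As far as these compounds go, it is also open whether chloro would keep its lead on another aromatic carbon of the same ring, or with the ethyl ester of the shared core replaced by a carboxylic acid.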